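Swapping trifluoromethyl for 4-methylpiperazinyl on the amide-linked ring

The source may report more compounds than this note shows. Statements on the series, on what has been measured and on what is new or still open speak of the compounds shown alone.

Measured so far:
compound 1 `CC(C)[C@H](C(=O)Nc1ncc(C(F)(F)F)s1)c1ccc(Cl)cc1` – 1500 nM
compound 2 `CC(C)(C)[C@H](C(=O)Nc1ncc(C(F)(F)F)s1)c1ccc(Cl)cc1` – 1500 nM

In a functional assay on CHO cells for agonist activity at Free fatty acid receptor 2 (Homo sapiens), read by cAMP accumulation (on this read-out lower numbers stand for stronger inhibition and higher numbers for weaker inhibition), compound 1 gives 1500 nM and compound 2 gives 1500 nM. Going by the values given here, the only measured step, no change at the digits printed from compound 1 to compound 2 (within the scatter), concerns a methyl added on the saturated chain carbon and leaves the read-out where it was; compound 2 therefore stands level with compound 1 in this assay.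

Compound 3 `CN1CCN(c2cnc(NC(=O)[C@H](c3ccc(Cl)cc3)C(C)(C)C)s2)CC1` differs from compound 2 by 4-methylpiperazin-1-yl in place of trifluoromethyl on an aromatic carbon, on an aromatic carbon of the five-membered aromatic ring with 1 nitrogen and 1 sulfur, next to the ring sulfur. Among the compounds with values here, no measured step touches this ring or exchanges a group of this kind, so the earlier step gives no guidance on direction or size. With nothing to lean on, compound 3 is expected to sit near compound 2, so that the estimated step of a 1.3-fold higher number from compound 2 to compound 3 (0.12 log units; within the scatter) is small, but the uncertainty is wide. The estimate for compound 3 in this assay is 2000 nM, within 300 nM to 15000 nM.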

Compound 3, half-maximal inhibitory concentration: 3800 nM
Estimate against measurement, compound 3: 1.9-fold (0.28 log units) below; the measured number falls inside the stated range.
By their numbers in this assay, from the lowest: compounds 1 and 2 (each within the scatter of the next); then compound 3.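

In this assay, going by these compounds alone, the aromatic carbon next to the ring sulfur proves to be a place where the read-out can move: 4-methylpiperazin-1-yl in place of trifluoromethyl gives a 2.5-fold higher number from compound 2 to compound 3 (0.40 log units; beyond the scatter) while the only earlier step, on the saturated chain carbon, left the number where it was. The position thus accepts a six-membered non-aromatic ring with two hetero atoms at only a modest cost in the read-out. Nothing available here explains the rise in the number.

As far as these compounds go, whether a morpholine, an open-chain amine such as dimethylamino or a simple chlorine at this carbon would give a lower or a higher number remains open. Also open, from the compounds shown here alone, is whether the methyl on the piperazine matters, and whether the same exchange would shift the number similarly on the core of compound 1.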